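Ring size at the triazole nitrogen and cell potency

The source may hold more compounds than are shown below. What is called first, only, known or untested is meant among the compounds shown, and "the series" means these compounds.

Measured compounds:
compound 1 `CN1C(=S)[C@@H](NC(=O)c2nc(Cc3ccccc3)n(C)n2)COc2ccccc21` — 2.5 nM
compound 2 `CN1C(=S)[C@@H](NC(=O)c2nc(Cc3ccccc3)n(CCCCCC#N)n2)COc2ccccc21` — 3830 nM
compound 3 `CN1C(=S)[C@@H](NC(=O)c2nc(Cc3ccccc3)n(C3CCC3)n2)COc2ccccc21` — 181 nM

In a functional assay on HT-29 cells (Homo sapiens) for inhibition, read by luminescence and CellTiter-Glo, with a stated time of 24 h (a higher number here means that more compound is needed for the effect, a lower number that less compound is needed), compound 3 stands second highest of the three numbers, its nearest neighbour being compound 2 and its furthest compound 1. Compound 4 `CN1C(=S)[C@@H](NC(=O)c2nc(Cc3ccccc3)n(C3CCNCC3)n2)COc2ccccc21` differs from compound 3 by piperidin-4-yl in place of cyclobutyl on an aromatic nitrogen. Within the data shown here, the steps that bear on this change are a 72-fold higher number from compound 1 to compound 3 (1.86 log units; beyond the scatter) and a 21-fold lower number from compound 2 to compound 3 (1.33 log units; beyond the scatter), together with a 1500-fold higher number from compound 1 to compound 2 (3.19 log units; beyond the scatter): both larger groups on the aromatic nitrogen gave markedly higher numbers than methyl, while the cyclobutyl ring sat well below the chain. Piperidin-4-yl is a larger ring than cyclobutyl, so in this assay a moderate step upward beyond the scatter is expected, a 2.5-fold higher number from compound 3 to compound 4 (0.40 log units; beyond the scatter). Compound 4 is therefore estimated at 450 nM, within a range from 100 nM to 2000 nM.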

Compound 4, half-maximal effective concentration: 1000 nM
Compound 4: the middle estimate sits 2.2-fold (0.35 log units) below what was measured; the measured number falls inside the stated range.
By their numbers in this assay, from the lowest: compound 1; then compound 3; then compound 4; then compound 2.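

In this assay the piperidin-4-yl ring gives a 5.5-fold higher number from compound 3 to compound 4 (0.74 log units; beyond the scatter) and a 400-fold higher number from compound 1 to compound 4 (2.60 log units; beyond the scatter) on this aromatic nitrogen, so a ring carrying a nitrogen does not bring the number back toward that of methyl. It still stands under the 5-cyanopentyl chain, with a 3.8-fold lower number from compound 2 to compound 4 (0.58 log units; beyond the scatter) here, third from the lowest of the four groups. Nothing available accounts for this order.

Cyclobutyl and piperidin-4-yl differ in both ring size and the ring nitrogen, so the two changes cannot be told apart here. From the compounds shown here alone, a cyclohexyl ring would separate them, and how a cyclopropyl ring stands against methyl remains open.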